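A Methyl Added to the Acid Chain of Compound 3

This account rests on a few compounds, and the source may have more. Where it says the series, first, only, none or still open, it means among the compounds named here.

In a functional assay on DU-145 cells (Homo sapiens) for cytotoxicity, read by trypan blue exclusion, with a stated time of 96 h (on this read-out higher numbers stand for weaker inhibition and lower numbers for stronger inhibition), compound 1 `COc1cc(OC)c(/C=C/S(=O)(=O)Nc2ccc(OC)c(O)c2)c(OC)c1` gives 30 nM. Compound 2 `COC(=O)C(Nc1cc(NS(=O)(=O)/C=C/c2c(OC)cc(OC)cc2OC)ccc1OC)c1ccccc1` gives 2500 nM, and compound 3 `COc1cc(OC)c(/C=C/S(=O)(=O)Nc2ccc(OC)c(NCC(=O)O)c2)c(OC)c1` gives 400 nM. Compound 3 therefore holds the second highest of the three numbers, below compound 2 and above compound 1.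

Compound 4 `COc1cc(OC)c(/C=C/S(=O)(=O)Nc2ccc(OC)c(NC(C)C(=O)O)c2)c(OC)c1` has not yet been measured. It differs from compound 3 in one place: methyl in place of hydrogen on a saturated chain carbon bound to a carbonyl carbon and a nitrogen on an aromatic ring. This puts methyl in place of hydrogen on a saturated chain carbon bound to a carbonyl carbon and a nitrogen on an aromatic ring, so carboxymethyl becomes 1-carboxyethyl.

Two measured steps involve the carboxymethyl group. Putting (carboxymethyl)amino in place of hydroxy gave a 13-fold higher number from compound 1 to compound 3 (1.12 log units; beyond the scatter). Putting carboxymethyl on the nitrogen in place of the larger group found there in compound 2 gave a 6.3-fold lower number from compound 2 to compound 3 (0.80 log units; beyond the scatter). Within the data shown here, both were much bigger structural changes than a single methyl, and no measured step isolates a methyl alone. Only a small move toward weaker inhibition is therefore expected, probably not clearly beyond the scatter.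

The expected step is a 1.4-fold higher number from compound 3 to compound 4 (0.14 log units; within the scatter). Compound 4 is estimated at 550 nM, with an expected range from 170 nM to 1800 nM.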

Compound 4, half-maximal inhibitory concentration: 40 nM
Compound 4: middle estimate off by 14-fold (1.14 log units), on the high side; the whole stated range lies above it.
By their numbers in this assay, from the lowest: compounds 1 and 4 (each within the scatter of the next); then compound 3; then compound 2.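

On the saturated chain carbon bound to a carbonyl carbon and a nitrogen on an aromatic ring, methyl in place of hydrogen adds a single carbon, yet in this assay it gives a 10-fold lower number from compound 3 to compound 4 (1.00 log units; beyond the scatter), so this position responds strongly to even the smallest added group. The earlier steps shown here swapped whole groups, and they left open whether a chain ending in a carboxylic acid on this nitrogen could match the hydroxy of compound 1; the (1-carboxyethyl)amino group now gives a 1.3-fold higher number from compound 1 to compound 4 (0.12 log units; within the scatter), and against the larger group on the nitrogen of compound 2 it gives a 63-fold lower number from compound 2 to compound 4 (1.80 log units; beyond the scatter). No measurement shown here offers a reason for the effect of this methyl.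

Whether an ethyl group or a longer chain on the same carbon would keep this value remains an open question. It is also unknown whether the carboxylic acid of the 1-carboxyethyl chain matters for the result, which a methyl ester or an amide in its place could test.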